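Swapping phenoxy for a chloro-fluoro-benzyl: expected acidity

The source may hold more compounds than are shown below. What is called first, only, known or untested is meant among the compounds shown, and "the series" means these compounds.

This account compares compound 2 `COc1cccc(CNCCCNc2ccnc3cc(Oc4ccccc4)ccc23)c1O` with compound 4 `COc1cccc(CNCCCNc2ccnc3cc(Cc4ccc(F)cc4Cl)ccc23)c1O` in a physicochemical assay for acid dissociation. Compound 2 gives 9.28, level with compound 1 `c1ccc(Oc2ccc3c(NCCCNCc4ccco4)ccnc3c2)cc1`, which gives 9.28; compound 3 `COc1ccc(F)cc1CNCCCNc1ccnc2cc(Cc3ccc(C#N)cc3)ccc12` gives 9.47, a number that stands within the scatter of both. The change to compound 4 is 2-chloro-4-fluorobenzyl in place of phenoxy on an aromatic carbon. Going by the values given here, no measured step alters this position alone: the only single-site step, no change at the digits printed from compound 1 to compound 2 (within the scatter), concerns the chain-bound aromatic group and not the phenoxy site. Compound 3 already carries a benzyl-type group at that site and its value sits close to compound 2, so no shift beyond the scatter is expected for compound 4, with a number 0.07 log units higher from compound 2 to compound 4 (within the scatter). Compound 4 is therefore estimated at 9.35, between 9 and 9.7.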

Compound 4, acid dissociation constant: 9.47
Compound 4: the middle estimate sits 0.12 log units below what was measured; low and high end bracket the measured number.
By their numbers in this assay, from the lowest: compounds 1, 2, 3 and 4 (each within the scatter of the next).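

At this aromatic carbon, this assay now has a step that alters the site alone: 2-chloro-4-fluorobenzyl in place of phenoxy gives a number 0.19 log units higher from compound 2 to compound 4 (within the scatter). On this read-out, the two groups are therefore not told apart at this position, even though the entering group carries chlorine and fluorine and lacks the oxygen of phenoxy. Nothing available explains why the two groups read alike. Going by these compounds, what stays open is whether an amine or a carboxylic acid at this same aromatic carbon would move the number in this assay beyond the scatter.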